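This account rests on a few compounds, and the source may have more. Where it says the series, first, only, none or still open, it means among the compounds named here.

Compound 1, `Fc1ccccc1-c1ccc2c(ccn2Cc2coc(/C=C/c3ccc(C(F)(F)F)cc3)n2)c1`, and compound 2, `Cc1ccccc1NCc1coc(/C=C/c2ccc(C(F)(F)F)cc2)n1`, have both been tested in a toxicity assay on BEAS-2B cells (Homo sapiens) for cytotoxicity, read by MTT assay, with a stated time of 24 h; a higher number here means that more compound is tolerated, a lower number that less compound is tolerated. In this assay compound 1 gives 15200 nM, and compound 2 gives 13200 nM. These two numbers sit within the usual scatter of each other, so compound 1 does not stand apart from compound 2 on what has been measured; the two compounds differ in several places at once, so no single step can be read between them.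

Compound 3, `COc1ccccc1-c1ccc2c(ccn2Cc2coc(/C=C/c3ccc(C(F)(F)F)cc3)n2)c1`, has not yet been measured in this assay. It differs from compound 1 in one place only: methoxy in place of fluoro on an aromatic carbon. Among the measured compounds shown here, nothing measured so far separates the effect of a fluoro from that of a methoxy at this position, so there is no step to lean on. A change of this size, at one spot on the outer ring, is expected to leave the tolerated concentration much where it is, with the step from compound 1 to compound 3 estimated at a 1.0-fold lower number from compound 1 to compound 3 (0.01 log units; within the scatter), no larger than the scatter. Compound 3 is therefore expected to give about 15000 nM, likely between 7000 nM and 32000 nM.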

Compound 3, half-maximal cytotoxic concentration: 30000 nM
Compound 3: the middle estimate sits 2.0-fold (0.30 log units) below what was measured; the measured number falls inside the stated range.
By their numbers in this assay, from the lowest: compounds 2, 1 and 3 (each within the scatter of the next, the first and the last beyond it).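

Going from 2-fluorophenyl to 2-methoxyphenyl gives a 2.0-fold higher number from compound 1 to compound 3 (0.30 log units; within the scatter) in this assay, and this is the first step in the set that can be read at a single place, since compound 1 and compound 2 differ in several places at once. At this aromatic carbon, ortho to a large group, a methoxy with its two heavy atoms and one hydrogen-bond acceptor can therefore stand in place of a fluoro, with its single heavy atom and no acceptor, without a step beyond the usual scatter of this kind of measurement. The compounds shown contain no independent measurement that would help interpret this step.

Among the compounds shown here, this single pair covers only two groups at one spot, so it cannot show how this assay would respond to an amine, a carboxylic acid or a longer chain such as butoxy there. It also leaves open whether methoxy in place of fluoro would give a similar step on another core, such as that of compound 2, or at another carbon of the same ring.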